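From compound 2 to compound 3

This account rests on a few compounds, and the source may have more. Where it says the series, first, only, none or still open, it means among the compounds named here.

Measured in a functional assay, read by fluorescence and spectrophotometry, with a stated time of 1 h; on this read-out lower numbers stand for an effect already at smaller amounts and higher numbers for an effect only at larger amounts of compound:
- compound 1 `O=S(=O)(/C=C/c1ccc(O)c(O)c1)CC1CCCN1`: 13800 nM
- compound 2 `O=S(=O)(/C=C/c1ccc(O)c(O)c1)CCC1CCCC1`: 6800 nM

Of the two numbers measured in this assay, compound 2 holds the lower, at 6800 nM. Compound 3 `O=S(=O)(/C=C/c1ccc(O)c(O)c1)CCCC1CCCC1` has not yet been measured, and its structure differs from that of compound 2 as follows: cyclopentylmethyl in place of cyclopentyl on a saturated chain carbon, two bonds along the chain from a sulfonyl sulfur. Among the compounds with values here, only one measured step bears on this change, a 2.0-fold lower number from compound 1 to compound 2 (0.31 log units; beyond the scatter), and it is modest and exchanged a different group. A step beyond the scatter is therefore not expected, though a slightly lower number is favoured. The expected change is a 1.3-fold lower number from compound 2 to compound 3 (0.12 log units; within the scatter). Compound 3 is estimated at 5200 nM, with an expected range of 2200 nM to 12000 nM.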

Compound 3, half-maximal effective concentration: 6300 nM
Beside the measured number, compound 3's estimate is 1.2-fold (0.08 log units) below it, within the range that was stated.
By their numbers in this assay, from the lowest: compounds 3 and 2 (each within the scatter of the next); then compound 1.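

In this assay, cyclopentylmethyl in place of cyclopentyl on a saturated chain carbon, two bonds along the chain from a sulfonyl sulfur, gives a 1.1-fold lower number from compound 2 to compound 3 (0.03 log units; within the scatter), so this position accepts the one added carbon with no change that can be read. Set against the pyrrolidin-2-yl group, the 2-cyclopentylethyl group gives a 2.2-fold lower number from compound 1 to compound 3 (0.34 log units; beyond the scatter), so the separation from compound 1 persists with the longer group. No evidence here bears on this result.

On these data alone, whether a still longer chain ending in cyclopentyl, or a carboxylic acid in place of the ring, would move the number beyond the scatter stays open.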